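The source may report more compounds than this note shows. Statements on the series, on what has been measured and on what is new or still open speak of the compounds shown alone.

Measured so far in a functional assay on A2780 cells (Homo sapiens) for antiproliferative activity, read by MTT assay, with a stated time of 48 h; a higher number here means a weaker inhibitor, a lower number a stronger inhibitor:
- Compound 1 `COc1ccc(-c2nc3cnccc3n2-c2cc(OC)c(OC)c(OC)c2)cc1O`: > 20000 nM, a limit of the assay and not a number
- Compound 2 `COc1ccc(-c2cc3c(cn2)[nH]c(=O)n3-c2cc(OC)c(OC)c(OC)c2)cc1F`: 730 nM
- Compound 3 `COc1ccc(-c2cc3c(cn2)[nH]c(=O)n3-c2cc(OC)c(OC)c(OC)c2)cn1`: 990 nM

For the measured compounds named here, only two real numbers exist here, and compound 2 holds one of them. Going by the values given here, the gap to its sole neighbour is small: a 1.4-fold higher number from compound 2 to compound 3 (0.13 log units; within the scatter). The two therefore stand level.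

Compound 4 `COc1ccc(-c2cc3c(cn2)[nH]c(=O)n3-c2cc(OC)c(OC)c(OC)c2)cc1N` keeps everything in compound 2 except one group: amino in place of fluoro on an aromatic carbon. In other words, 3-fluoro-4-methoxyphenyl becomes 3-amino-4-methoxyphenyl. Among the compounds with values here, no measured step makes this exact swap. The closest guide is a 1.4-fold higher number from compound 2 to compound 3 (0.13 log units; within the scatter), with 6-methoxypyridin-3-yl in place of 3-fluoro-4-methoxyphenyl, so no step beyond the scatter is expected in this assay. A single step is thin support, so the expected range is kept wide. The expected change is a 1.5-fold lower number from compound 2 to compound 4 (0.16 log units; within the scatter). For compound 4 the estimated value is 500 nM, with an expected range from 100 nM to 2500 nM.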

Compound 4, half-maximal inhibitory concentration: 640 nM
Compound 4: middle estimate off by 1.3-fold (0.11 log units), on the low side; the measured number falls inside the stated range.
By their numbers in this assay, from the lowest: compounds 4, 2 and 3 (each within the scatter of the next). At a limit, above all of these: compound 1.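

In this assay, this place, ortho to a methoxy group, takes amino in place of fluoro with no step beyond the scatter: a 1.1-fold lower number from compound 2 to compound 4 (0.06 log units; within the scatter). Here a hydrogen-bond donor and a hydrogen-bond acceptor enter where fluoro has neither, a swap on the carbon ring that the earlier step did not test, and 3-amino-4-methoxyphenyl in place of 6-methoxypyridin-3-yl also stays within the scatter: a 1.5-fold lower number from compound 3 to compound 4 (0.19 log units; within the scatter). Nothing measured here gives a reason for this level reading.

Open, from the compounds shown here alone, is how this place responds to plain hydrogen, or to something larger than amino, such as an acetamide or a carboxylic acid. The numbers for compound 2, compound 3 and compound 4 all lie within the scatter of one another, and no change shown on their shared core has yet moved the number beyond it.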